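The source may report more compounds than this note shows. Statements on the series, on what has been measured and on what is new or still open speak of the compounds shown alone.

Working notes on the series.

Compound 1 `Cc1ccccc1-c1cnc(NC(=O)c2ccc(F)cc2)n1C` is the reference here. In a toxicity assay on THP-1 cells (Homo sapiens) for inhibition (on this read-out higher numbers stand for lower toxicity in this test and lower numbers for higher toxicity in this test), compound 1 returns only a limit of the assay, > 50000 nM, so its standing on this read-out is known merely as a bound and not as a number. One other compound in this set reaches that same bound, (the limit of > 50000 nM in this assay, at which 1 of the 3 values shown sits).

Compound 2 `Cn1c(-c2ccccc2[N+](=O)[O-])cnc1NC(=O)c1ccc(F)cc1` gives 31000 nM in this assay. Going by the values given here, the measured step from compound 1 to compound 2 is an at least 1.6-fold lower number from compound 1 to compound 2 (0.20 log units; that floor lies within the scatter), and it concerns a nitro in place of methyl, a change that has no counterpart in the step considered below. Compound 3 `Cn1c(-c2cccc(Cl)c2)cnc1NC(=O)c1ncc[nH]1` gives 55000 nM in this assay; it differs from compound 1 in more than one place, so only its value is taken as shown.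

Compound 4 `Cn1c(-c2cccc(F)c2)cnc1NC(=O)c1ccc(F)cc1` differs from compound 1 as follows: 3-fluorophenyl in place of 2-methylphenyl on an aromatic carbon. Among the compounds with values here, no measured step in the set covers this exchange, so no direction beyond the scatter is expected, and compound 1 itself is only a bound. The step from compound 1 to compound 4 is estimated at a number no higher from compound 1 to compound 4 (the limit leaves the size open), that is, no movement beyond the scatter. Compound 4 is therefore expected to give 50000 nM in this assay, within a range from 20000 nM to 100000 nM, with a fair chance that only a limit is reported.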

Compound 4, half-maximal cytotoxic concentration: 58000 nM
Estimate against measurement, compound 4: 1.2-fold (0.06 log units) below, within the range that was stated.
By their numbers in this assay, from the lowest: compounds 2, 3 and 4 (each within the scatter of the next).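

The step from compound 1 to compound 4 cannot be read, as compound 1 stands only at a limit of the assay in this assay: the limit of > 50000 nM in this assay, at which 1 of the 4 values shown sits.

The compounds shown leave open how far 3-fluorophenyl in place of 2-methylphenyl moves the number in this assay, and where compound 1 itself lies on this read-out.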